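The source may hold more compounds than are shown below. What is called first, only, known or untested is meant among the compounds shown, and "the series" means these compounds.

Compound 1 `CC(C)(C)OC(=O)N1CCC(Oc2ncnc3c2CCN3c2ccc(S(C)(=O)=O)cc2F)CC1`: 20 nM
Compound 2 `CCS(=O)(=O)N1CCC(Oc2ncnc3c2CCN3c2ccc(S(C)(=O)=O)cc2F)CC1`: 1580 nM
Compound 3 `CN(C)C(=O)CN1CCC(Oc2ncnc3c2CCN3c2ccc(S(C)(=O)=O)cc2F)CC1`: > 10000 nM

These three compounds share one core and differ only in the group carried on an amine nitrogen in a ring. In a functional assay on CHO-K1 cells for agonist activity at Glucose-dependent insulinotropic receptor (Homo sapiens), read by a luciferase reporter, with a stated time of 5 h (on this read-out higher numbers stand for an effect only at larger amounts of compound and lower numbers for an effect already at smaller amounts), compound 1 gives 20 nM. Compound 2 gives 1580 nM in this assay. For compound 3 this assay reports no number but only a limit, > 10000 nM. Compound 3 therefore stands at the weak end of everything measured here, as the limit of > 10000 nM in this assay, at which 1 of the 3 values shown sits, shows.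

Compound 4 `CS(=O)(=O)c1ccc(N2CCc3c(OC4CCN(C5=NCCCN5)CC4)ncnc32)c(F)c1` differs from compound 3 by a group of 6 heavy atoms (4 carbon, 2 nitrogen; one six-membered non-aromatic ring with 2 hetero atoms) in place of a group of 6 heavy atoms (4 carbon, 1 nitrogen, 1 oxygen; no ring), on an amine nitrogen in a ring. The measured steps that touch the same nitrogen were all large: a 79-fold higher number from compound 1 to compound 2 (1.90 log units; beyond the scatter), an at least 500-fold higher number from compound 1 to compound 3 (2.69 log units; beyond the scatter) and an at least 6.3-fold higher number from compound 2 to compound 3 (0.80 log units; beyond the scatter). They show that the group on this nitrogen moves the read-out by a great deal, yet none of them involves the ring-containing group that enters in compound 4, so the direction of the new step is open. Because compound 3 already sits at the limit > 10000 nM, little room remains for a worse outcome, and a gain is at least as plausible as a loss. The expected step is an at least 5.0-fold lower number from compound 3 to compound 4 (0.69 log units; beyond the scatter), with wide uncertainty. Compound 4 is thus estimated at 2000 nM, in the range 150 nM to 20000 nM.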

Compound 4, half-maximal effective concentration: 2000 nM
Compound 4: the middle estimate sits on the measured number at the digits printed; the range from low to high includes it.
By their numbers in this assay, from the lowest: compound 1; then compounds 2 and 4 (each within the scatter of the next). At a limit, above all of these: compound 3.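

Compound 3 stands at a limit of the assay and not at a number: the limit of > 10000 nM in this assay, at which 1 of the 4 values shown sits.

Starting from that limit, the ring-containing group gives a value that can be read in this assay, with an at least 5.0-fold lower number from compound 3 to compound 4 (0.69 log units; beyond the scatter), so exchanging one group of 6 heavy atoms for another on this amine nitrogen is enough to bring the read-out back into the measured range. Against ethylsulfonyl the result is a 1.3-fold higher number from compound 2 to compound 4 (0.10 log units; within the scatter), so these two differently built groups cannot be told apart here, while tert-butoxycarbonyl keeps its clear lead, with a 100-fold higher number from compound 1 to compound 4 (2.00 log units; beyond the scatter).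

From the compounds shown here alone, whether the gap to compound 1 can be narrowed by another carbamate, such as methoxycarbonyl, or by a quite different group, such as benzyl, on this nitrogen remains open. Going by these compounds, it is equally open whether the ring of the new group matters at all, a question that an open-chain guanidine at the same place would help to answer.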